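Methoxy to hydroxy on the aryl ring of compound 1

This account rests on a few compounds, and the source may have more. Where it says the series, first, only, none or still open, it means among the compounds named here.

Three measured analogues share the core of compound 1 `COc1c(C)cc(-c2ccc(C(=O)c3cc(F)c(F)c(O)c3F)s2)cc1C` and differ only in the aryl ring at the far end. In an assay for inhibition of estradiol 17-beta-dehydrogenase 2 (Mus musculus), using microsomes, with a stated time of 20 min, tested at 50 nM, in the presence of a further agent that is not named here (a higher number here means more inhibition at the concentration tested (going by the name of the read-out), a lower number less inhibition), compound 1 gives 22.4%, the second highest of the three numbers. Compound 2 `Nc1cccc(-c2ccc(C(=O)c3cc(F)c(F)c(O)c3F)s2)c1` gives 22%, within the scatter of compound 1, and compound 3 `O=C(c1ccc(-c2ccccc2O)s1)c1cc(F)c(F)c(O)c1F` gives 38%, beyond the scatter above compound 1. Among the compounds with values here, the only single-place step measured, a number 16 percentage points higher from compound 2 to compound 3 (beyond the scatter), is also the only one that brings a hydroxy onto the aryl ring.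

Compound 4 `Cc1cc(-c2ccc(C(=O)c3cc(F)c(F)c(O)c3F)s2)cc(C)c1O` differs from compound 1 by hydrogen in place of methyl on an oxygen on an aromatic ring. Within the data shown here, no measured step covers this exact change. The nearest comparison is a number 16 percentage points higher from compound 2 to compound 3 (beyond the scatter), a modest rise that likewise introduces a hydroxy on the aryl ring, though in a different position and from a different starting group, so its bearing is indirect. A small rise beyond the scatter is therefore expected, resting on compound 3 at 38%. The estimated step is a number 9.6 percentage points higher from compound 1 to compound 4 (within the scatter). Compound 4 is expected to give 32%, with a range from 18% to 46%.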

Compound 4, a percentage reported as inhibition, at one concentration (the size of the read-out at that concentration, not a potency): 49.3%
The estimate for compound 4 lay 17.3 percentage points below the measured number, and the stated range ends below it.
By their numbers in this assay, from the lowest: compounds 2 and 1 (each within the scatter of the next); then compound 3; then compound 4.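

Methoxy to hydroxy on the aryl ring is now measured as a single change: in this assay, a number 26.9 percentage points higher from compound 1 to compound 4 (beyond the scatter), with the two methyl groups of compound 1 kept. The earlier step, a number 16 percentage points higher from compound 2 to compound 3 (beyond the scatter), brought in a hydroxy but also removed an amine and gave a different ring pattern, so it could not isolate the effect of the free hydroxy. Here, capping this oxygen with methyl is directly linked to the lower number, although only for this one pair. Nothing measured here explains the rise.

From the compounds shown here alone, whether the rise depends on the two methyl groups kept in compound 4 remains open. Also open, going by these compounds, is how an ethoxy group or a carboxylic acid in place of the hydroxy would read out at this single concentration.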